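A few compounds are considered here, and "the series" means these few. Any claim that something is new, unique, unknown or untested is made for them only; others in the source may bear on it.

Compound 1 `CO[C@@H]1[C@H](N(C)c2ncc(-c3c[nH]c4ccccc34)s2)C[C@H]2O[C@]1(C)n1c3ccccc3c3c4c(c5c6cc(Br)ccc6n2c5c31)C(=O)NC4` — in an ADME assay on PBMC cells (Homo sapiens) for cytotoxicity, read by CellTiter-Glo, with a stated time of 72 h (a higher number here means a weaker inhibitor, a lower number a stronger inhibitor), compound 1 gives > 10000 nM, a limit of the assay rather than a number.
Compound 2 `CO[C@@H]1[C@H](N(C)c2ncc(-c3c[nH]c4ccc(Cl)cc34)s2)C[C@H]2O[C@]1(C)n1c3ccccc3c3c4c(c5c6cc(Br)ccc6n2c5c31)C(=O)NC4` — in this assay compound 2 gives > 10000 nM, likewise a limit.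

Going by the values given here, on these numbers compound 2 stands where compound 1 does: its value in this assay is a limit, and the one other value shown is also a limit, so compound 2 is neither stronger nor weaker than compound 1 here. Among the compounds with values here, the single measured step, a step that the two limits leave unreadable from compound 1 to compound 2, cannot be given a size, since both of its ends sit at the limit (the limit of > 10000 nM in this assay, at which 2 of the 2 values shown sit).

Compound 3 `COc1ccc2[nH]cc(-c3cnc(N(C)[C@@H]4C[C@H]5O[C@@](C)([C@@H]4OC)n4c6ccccc6c6c7c(c8c9cc(Br)ccc9n5c8c64)C(=O)NC7)s3)c2c1` is the next compound. It differs from compound 2 in one place: methoxy in place of chloro on an aromatic carbon. Within the data shown here, the only step that bears on it, the one measured step, touched this same aromatic carbon and left the readout at the limit, so it shows no direction and no size. The expectation for compound 3 in this assay is therefore a step that the limit leaves unreadable from compound 2 to compound 3, no movement beyond the scatter, with compound 3 most likely at the limit once more. Compound 3 is estimated at 20000 nM, within a range from 8000 nM to 60000 nM.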

Compound 3, half-maximal inhibitory concentration: > 10000 nM
Compound 3 was reported as a limit; the forecaster's own chance of this, stated with the estimate: 85%; the middle value does not contradict the limit.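

Compound 3 reads as a limit, as compound 1 and compound 2 do, so no step among these three compounds can be read in this assay: the limit of > 10000 nM in this assay, at which 3 of the 3 values shown sit. Left open is how far apart the three compounds truly lie, and whether hydrogen, chloro and methoxy on this aromatic carbon differ at all in this assay.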